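4-Methoxybenzyl in place of 4-fluorophenyl: an untested step

A few compounds are considered here, and "the series" means these few. Any claim that something is new, unique, unknown or untested is made for them only; others in the source may bear on it.

Among the measured compounds shown here, compound 1 `C=C(Br)C(=O)Nc1cccc(-c2cn3nc(-c4ccc(F)cc4)sc3n2)c1` is the only member of the set with a numerical reading. In a functional assay on CCRF-CEM cells (Homo sapiens) for inhibition, read by cell counting, with a stated time of 3 days (on this read-out lower numbers stand for stronger inhibition and higher numbers for weaker inhibition), compound 1 gives 830 nM. For the measured compounds named here, compound 2 `COc1cccc(-c2nn3cc(-c4cccc(N)c4)nc3s2)c1` differs from compound 1 in more than one place, so no single step connects the two. For compound 2 this assay reports > 250000 nM, a limit of the assay and not a number, matching (the limit of > 250000 nM in this assay, at which 1 of the 2 values shown sits).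

Compound 3 `C=C(Br)C(=O)Nc1cccc(-c2cn3nc(Cc4ccc(OC)cc4)sc3n2)c1` has not been measured. It differs from compound 1 by 4-methoxybenzyl in place of 4-fluorophenyl on an aromatic carbon. Going by the values given here, no measured pair differing in one place is available, so the size of this change in this assay is unknown.

The change is expected to cost some potency, with the step of a 3.0-fold higher number from compound 1 to compound 3 (0.48 log units; beyond the scatter) estimated to lie beyond the usual scatter but well short of the limit. Compound 3 is estimated at 2500 nM, with a range from 600 nM to 12000 nM.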

Compound 3, half-maximal inhibitory concentration: 2300 nM
For compound 3 the middle estimate is 1.1-fold (0.04 log units) above the measured one; measured number inside the range.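

This position now has its first measured step: in this assay, 4-methoxybenzyl in place of 4-fluorophenyl gives a 2.8-fold higher number from compound 1 to compound 3 (0.44 log units; beyond the scatter), a modest loss. The aromatic carbon next to the ring nitrogen and next to the ring sulfur therefore accepts the larger group while inhibition stays in a measurable range, with compound 3 at 2300 nM. No measurement shown here accounts for the size of this step.

The step alters the ring substituent and its link to the core together, and the share of each in the loss remains unresolved. Also open, from the compounds shown here alone, is how an amine, a carboxylic acid or a longer chain on this carbon would read in this assay.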